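Isopropyl in Place of Chloro: Expected Shift in Binding

A few compounds are considered here, and "the series" means these few. Any claim that something is new, unique, unknown or untested is made for them only; others in the source may bear on it.

Of the compounds shown here, three have been measured in an assay on HEK293 cells for binding affinity to 5-hydroxytryptamine receptor 7 (Homo sapiens), read by radioligand binding, tested at 1 uM; on this read-out higher numbers stand for more inhibition at the one concentration tested (going by the name of the read-out) and lower numbers for less inhibition. Compound 3 `CN1CCCN(CCn2ccc3ccc(Cl)cc32)CC1` gives 85%, the highest of the three numbers. Compound 1 `Brc1ccc2ccn(CCN3CCN4CCCC4C3)c2c1` gives 72% in this assay, a number beyond the scatter below that of compound 3. Compound 2 `CN1CCCN(CCn2ccc3cccc(Br)c32)CC1` gives 18%, far below both. Among the compounds with values here, no pair of these measured compounds differs in only one place, so no single step can be read from their values. Compound 4 `CC(C)c1ccc2ccn(CCN3CCCN(C)CC3)c2c1` has not yet been tested and differs from compound 3 in one place: isopropyl in place of chloro on an aromatic carbon. Without a measured step of this kind to lean on, a moderate drop beyond the scatter is expected, a number 17 percentage points lower from compound 3 to compound 4 (beyond the scatter). Compound 4 is estimated at 68%, within a range from 42% to 90%.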

Compound 4, a percentage reported as inhibition, at one concentration (the size of the read-out at that concentration, not a potency): 72%
Compound 4: middle estimate off by 4 percentage points, on the low side; the range from low to high includes it.
By their numbers in this assay, from the lowest: compound 2; then compounds 1 and 4 (each within the scatter of the next); then compound 3.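

In this assay, within the data shown here, the change from chloro to isopropyl gives the first single-place step in the set: a number 13 percentage points lower from compound 3 to compound 4 (beyond the scatter) is a modest loss. On this aromatic carbon, 3 heavy atoms of carbon can thus replace 1 chlorine, and compound 4 still gives 72% at the one concentration tested. Nothing measured here accounts for the step. On these data alone, whether a methoxy group or an amine on the same carbon would give a similar number stays open, as does whether isopropyl would give a similar step on the core of compound 1.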